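The source may hold more compounds than are shown below. What is called first, only, known or untested is meant among the compounds shown, and "the series" means these compounds.

The measured compounds:
Compound 1 `NCCOc1ccc([C@H]2CC[C@]3(CC2)OOC2(O3)C3CC4CC(C3)CC2C4)cc1` gives > 100 ug/mL in a physicochemical assay for solubility, read by nephelometry, measured as kinetic solubility, with a stated time of 30 min; on this read-out lower numbers stand for lower solubility and higher numbers for higher solubility.
Compound 2 `CC(C)(O)CNCCCOc1ccc([C@H]2CC[C@]3(CC2)OOC2(O3)C3CC4CC(C3)CC2C4)cc1` gives > 100 ug/mL in this assay.
Compound 3 `c1cc([C@H]2CC[C@]3(CC2)OOC2(O3)C3CC4CC(C3)CC2C4)ccc1OC1CCNCC1` gives > 100 ug/mL in this assay.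

In this assay compound 1 stands at a limit of the assay and not at a number. Compound 2 likewise reports only a limit. Compound 3 reports only a limit as well, so that (the limit of > 100 ug/mL in this assay, at which 3 of the 3 values shown sit). The steps a step that the two limits leave unreadable from compound 1 to compound 2 and a step that the two limits leave unreadable from compound 1 to compound 3, and also a step that the two limits leave unreadable from compound 2 to compound 3, have no readable size and no readable direction. Compound 4 `NC1CCN(S(=O)(=O)c2ccc([C@H]3CC[C@]4(CC3)OOC3(O4)C4CC5CC(C4)CC3C5)cc2)CC1` differs from compound 1 by (4-aminopiperidin-1-yl)sulfonyl in place of 2-aminoethoxy on an aromatic carbon. None of the three measured steps exchanges the group on the aromatic carbon for the kind of group that enters here, and none of them gives a readable size, so they offer no direction for this change. Compound 4 is therefore expected to sit at or near the same limit, and the step of a number no higher from compound 1 to compound 4 (the limit leaves the size open) is expected to lie within the scatter. The estimate for compound 4 in this assay is 100 ug/mL, with a range from 50 ug/mL to 200 ug/mL.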

Compound 4, solubility: 12.5 ug/mL
Compound 4: middle estimate off by 8.0-fold (0.90 log units), on the high side; the measured number lies below the stated range.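

In this assay, among these compounds, the aromatic carbon para to a large group now gives the first readable step, whereas the steps among compound 1, compound 2 and compound 3 cannot be read. Exchanging 2-aminoethoxy for (4-aminopiperidin-1-yl)sulfonyl gives an at least 8.0-fold lower number from compound 1 to compound 4 (0.90 log units; beyond the scatter), and the same entering group gives an at least 8.0-fold lower number from compound 3 to compound 4 (0.90 log units; beyond the scatter) in place of (piperidin-4-yl)oxy and an at least 8.0-fold lower number from compound 2 to compound 4 (0.90 log units; beyond the scatter) in place of 3-((2-hydroxy-2-methylpropyl)amino)propoxy. The full size of these steps stays open, as compound 1, compound 2 and compound 3 each stand at a limit of the assay and not at a number: the limit of > 100 ug/mL in this assay, at which 3 of the 4 values shown sit.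

The sulfonyl link and the 4-aminopiperidine ring enter together in compound 4, so the compounds shown do not separate the two. A carbonyl in place of the sulfonyl, or a 2-aminoethyl chain on the sulfonamide nitrogen in place of the ring, would be needed to tell them apart.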